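The source may report more compounds than this note shows. Statements on the series, on what has been measured and on what is new or still open speak of the compounds shown alone.

Measured so far in a functional assay on CCRF-CEM cells (Homo sapiens) for antiproliferative activity; on this read-out higher numbers stand for weaker inhibition and lower numbers for stronger inhibition:
compound 1, `COc1ccc(-c2cc(N)c(C(=O)c3cc(OC)c(OC)c(OC)c3)s2)cc1OC`: 20 nM
compound 2, `COc1cc(C(=O)c2sc(-c3ccc([N+](=O)[O-])cc3)cc2N)cc(OC)c1OC`: 99 nM
compound 3, `COc1cc(C(=O)c2sc(-c3ccc(I)cc3)cc2N)cc(OC)c1OC`: 150 nM

Compound 3 gives the highest number of the three; its nearest neighbour is compound 2, a gap within the scatter, while compound 1 lies furthest, a 7.5-fold higher number from compound 1 to compound 3 (0.88 log units; beyond the scatter). Compound 4, `COc1cc(C(=O)c2sc(-c3ccncc3)cc2N)cc(OC)c1OC`, carries the change (pyridin-4-yl in place of 4-iodophenyl on an aromatic carbon). For the measured compounds named here, the steps that bear on this position are a 5.0-fold higher number from compound 1 to compound 2 (0.69 log units; beyond the scatter), a 7.5-fold higher number from compound 1 to compound 3 (0.88 log units; beyond the scatter) and a 1.5-fold higher number from compound 2 to compound 3 (0.18 log units; within the scatter); the two exchanges away from 3,4-dimethoxyphenyl were modest losses, whereas iodo against nitro stayed within the scatter. Going by the values given here, no measured step places a pyridin-4-yl here, so compound 4 is expected to remain near compound 3, with a step of a 1.3-fold higher number from compound 3 to compound 4 (0.12 log units; within the scatter) in this assay, and its estimated value is 200 nM, ranging from 60 nM to 700 nM.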

Compound 4, half-maximal inhibitory concentration: 110 nM
Estimate against measurement, compound 4: 1.8-fold (0.26 log units) above; measured number inside the range.
By their numbers in this assay, from the lowest: compound 1; then compounds 2, 4 and 3 (each within the scatter of the next).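

Putting a nitrogen into the six-membered ring at this position does not separate the compound from its carbon-only analogues: pyridin-4-yl gives a 1.4-fold lower number from compound 3 to compound 4 (0.13 log units; within the scatter) and a 1.1-fold higher number from compound 2 to compound 4 (0.05 log units; within the scatter). The modest loss against 3,4-dimethoxyphenyl also holds for this ring, with a 5.5-fold higher number from compound 1 to compound 4 (0.74 log units; beyond the scatter), so compounds 2, 3 and 4 stand together, apart from compound 1.

Nothing available explains this grouping. Going by these compounds, it remains open whether a phenyl ring bearing a single methoxy group would come closer to compound 1, and how a morpholine at this position would compare.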